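Chloro to Fluoro: From Compound 3 to Compound 4

A few compounds are considered here, and "the series" means these few. Any claim that something is new, unique, unknown or untested is made for them only; others in the source may bear on it.

The measured compounds and their numbers:
compound 1, `CCCCCCCCS(=O)(=O)Nc1cc(-c2ccccc2-c2ccccc2)ccc1C(=O)O`, gives 17100 nM
compound 2, `CCCCCCCCS(=O)(=O)Nc1cc(-c2ccccc2OC)ccc1C(=O)O`, gives 16100 nM
compound 3, `CCCCCCCCS(=O)(=O)Nc1ccc(-c2cccc(Cl)c2)cc1C(=O)O`, gives 8900 nM

Compound 3 holds the lowest of the three numbers in an assay on mitochondria (strain BALB/c) for inhibition of glycerol-3-phosphate acyltransferase 1, mitochondrial (Mus musculus), read by scintillation counting, with a stated time of 10 min (on this read-out lower numbers stand for stronger inhibition and higher numbers for weaker inhibition), yet both gaps to its neighbours sit within the scatter of the method: compound 2 is nearest, compound 1 furthest, and neither gap reaches beyond the scatter, so compound 3 cannot be called the strongest of the three. Among the compounds with values here, the one step between measured compounds that differ in a single place, a 1.1-fold lower number from compound 1 to compound 2 (0.03 log units; within the scatter), was itself within the scatter.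

Compound 4, `CCCCCCCCS(=O)(=O)Nc1ccc(-c2cccc(F)c2)cc1C(=O)O`, differs from compound 3 in one place: fluoro in place of chloro on an aromatic carbon. Within the data shown here, no measured step touches this kind of exchange; the only step at hand, a 1.1-fold lower number from compound 1 to compound 2 (0.03 log units; within the scatter), concerns a different part of the shared core and shows a change that the method cannot separate from noise. On that footing the expectation is that the number for compound 4 stays close to that of compound 3, with a step of a 1.1-fold higher number from compound 3 to compound 4 (0.05 log units; within the scatter) expected, and no direction beyond the scatter. The estimate for compound 4 is 10000 nM, with an expected range from 4500 nM to 22000 nM.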

Compound 4, half-maximal inhibitory concentration: 37600 nM
For compound 4 the middle estimate is 3.8-fold (0.58 log units) below the measured one, and the stated range ends below it.
By their numbers in this assay, from the lowest: compounds 3, 2 and 1 (each within the scatter of the next); then compound 4.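

In this assay, fluoro in place of chloro gave a 4.2-fold higher number from compound 3 to compound 4 (0.63 log units; beyond the scatter), the first step among these compounds to lie beyond the scatter. It shows that this position, on an aromatic carbon meta to a large group, is sensitive to which halogen it carries: the exchange of one heavy atom for another, with no ring, hydrogen-bond donor, hydrogen-bond acceptor or net charge entering or leaving, is enough to weaken inhibition, and of the two halogens chloro gives the stronger inhibition here. Nothing measured among these compounds accounts for the size or direction of this step.

What the compounds leave open is whether chloro is the best choice at this position, since they do not show how a methyl, a trifluoromethyl or a nitrile there would compare with it. Within the data shown here, they also do not tell whether the same exchange would give a similar step with a shorter or longer chain in place of the one all four compounds share, or with the aryl group placed as it is in compound 1 and compound 2.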